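A few compounds are considered here, and "the series" means these few. Any claim that something is new, unique, unknown or untested is made for them only; others in the source may bear on it.

Measured compounds in an assay on HEK293 cells for displacement of a labelled ligand from NPC1-like intracellular cholesterol transporter 1 (Homo sapiens); a higher number here means a weaker inhibitor, a lower number a stronger inhibitor:
compound 1 `CCOC(=O)C1CCN(C(=O)CN2CN(c3ccccc3)C3(CCN(C(=O)c4ccc(C5CCCCC5)cc4)CC3)C2=O)CC1` gives 900 nM
compound 2 `CCOC(=O)C1CCN(C(=O)CN2CN(c3ccccc3)C3(CCN(C(=O)c4ccc(C(C)(C)C)cc4)CC3)C2=O)CC1` gives 3100 nM
compound 3 `CC(C)(C)OC(=O)NC1CCN(C(=O)CN2CN(c3ccccc3)C3(CCN(C(=O)c4ccc(C5CCCCC5)cc4)CC3)C2=O)CC1` gives 4800 nM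

Compound 2 stands second highest of the three numbers; its gap to compound 3 lies within the scatter, while compound 1 sits lower by a 3.4-fold higher number from compound 1 to compound 2 (0.54 log units; beyond the scatter).

Compound 4 `CC(C)(C)c1ccc(C(=O)N2CCC3(CC2)C(=O)N(CC(=O)NCCCN)CN3c2ccccc2)cc1` is unmeasured. Its change from compound 2 is (3-aminopropyl)amino in place of 4-(ethoxycarbonyl)piperidin-1-yl on a carbonyl carbon. Among the measured compounds shown here, no measured pair shows this change. For the measured compounds named here, the only step that touches the same region is a 5.3-fold higher number from compound 1 to compound 3 (0.73 log units; beyond the scatter), where the group on the saturated ring carbon was exchanged while the ring itself stayed; that gave a modest rise. Compound 4 loses the ring entirely, so that step is only a loose guide, and the direction of the step from compound 2 is open. The expectation is therefore a step of uncertain sign, most likely somewhat upward, a 1.6-fold higher number from compound 2 to compound 4 (0.21 log units; within the scatter), with wide bounds.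

Compound 4 is estimated in this assay at 5000 nM, expected to fall between 1500 nM and 20000 nM.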

Compound 4, half-maximal inhibitory concentration: 4200 nM
The estimate for compound 4 lay 1.2-fold (0.08 log units) above the measured number; the measured number falls inside the stated range.
By their numbers in this assay, from the lowest: compound 1; then compounds 2, 4 and 3 (each within the scatter of the next).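

In this assay, (3-aminopropyl)amino in place of 4-(ethoxycarbonyl)piperidin-1-yl on a carbonyl carbon gives a 1.4-fold higher number from compound 2 to compound 4 (0.13 log units; within the scatter). The earlier change at this end, a 5.3-fold higher number from compound 1 to compound 3 (0.73 log units; beyond the scatter), kept the ring, whereas here the ring and the ester both leave, and an open chain of 5 heavy atoms replacing the whole 4-(ethoxycarbonyl)piperidin-1-yl group gives a number that cannot be told from that of compound 2. Nothing available explains this outcome.

Going by these compounds, it remains open whether cyclohexyl in place of tert-butyl, read so far only with the ethoxycarbonyl group as a 3.4-fold higher number from compound 1 to compound 2 (0.54 log units; beyond the scatter), would have the same effect alongside the open chain. The role of the chain end is also unresolved, and a longer chain or a carboxylic acid in place of the terminal amine would test it.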